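A few compounds are considered here, and "the series" means these few. Any claim that something is new, unique, unknown or untested is made for them only; others in the source may bear on it.

Of the compounds shown here, three here have been measured and a fourth has not. Compound 1 `Cc1ccc(NC(=S)NC(=O)c2ccc(OCc3ccc(Cl)c(Cl)c3)cc2)cc1-c1nc2ccccc2[nH]1` carries a (3,4-dichlorobenzyl)oxy group, and in a functional assay on HT-29 cells (Homo sapiens) for inhibition, read by MTT assay, with a stated time of 48 h (on this read-out higher numbers stand for weaker inhibition and lower numbers for stronger inhibition), compound 1 gives 6270 nM. Compound 2 `Cc1ccc(NC(=S)NC(=O)c2ccc(OCc3ccc(Cl)cc3Cl)cc2)cc1-c1nc2ccccc2[nH]1` differs from compound 1 only by 2,4-dichlorophenyl in place of 3,4-dichlorophenyl on a saturated chain carbon bound to an oxygen on an aromatic ring. In this assay compound 2 gives 11600 nM, which is a 1.9-fold higher number from compound 1 to compound 2 (0.27 log units; within the scatter). Compound 3 `Cc1ccc(NC(=O)NC(=O)c2ccc(OCc3ccc(Cl)c(Cl)c3)cc2)cc1-c1nc2ccccc2[nH]1` has a different core from compound 1; how the two cores differ is not broken down here. In this assay compound 3 gives 1030 nM, the lowest of the three numbers, with both measured comparisons beyond the scatter.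

Compound 4 `Cc1ccc(NC(=O)NC(=O)c2ccc(OCc3ccc(Cl)cc3Cl)cc2)cc1-c1nc2ccccc2[nH]1` is the one still to be measured. It differs from compound 3 by 2,4-dichlorophenyl in place of 3,4-dichlorophenyl on a saturated chain carbon bound to an oxygen on an aromatic ring, the same change, at the same place, that separates compound 1 from compound 2. The step from compound 3 to compound 4 is expected to be a 1.8-fold higher number from compound 3 to compound 4 (0.27 log units; within the scatter), because the earlier example of this change gave only a 1.9-fold higher number from compound 1 to compound 2 (0.27 log units; within the scatter). Compound 4 is therefore estimated at 1900 nM, with a likely range from 900 nM to 4500 nM.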

Compound 4, half-maximal inhibitory concentration: 2620 nM
Compound 4: the middle estimate sits 1.4-fold (0.14 log units) below what was measured; measured number inside the range.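

In this assay, replacing the 3,4-dichlorophenyl with 2,4-dichlorophenyl on the core of compound 3 gives a 2.5-fold higher number from compound 3 to compound 4 (0.41 log units; beyond the scatter), so this step lies beyond the scatter, while the earlier step on the core of compound 1 lies within it. Even so, the two steps point the same way and the gap between them is small, so the change carried over from one core to the other with much the same size: the same change on two cores in this assay, a 1.9-fold higher number (0.27 log units; within the scatter) from compound 1 to compound 2 and a 2.5-fold higher number (0.41 log units; beyond the scatter) from compound 3 to compound 4, 1.4-fold (0.14 log units) apart, within the scatter of two such steps. Among the compounds shown here, this rests on only two pairs of compounds in a single assay, so it shows agreement between these two cores and neither establishes a rule for the whole series nor explains why the numbers move.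

The compounds shown leave open whether the step would look the same with other groups on the saturated chain carbon, such as a plain phenyl or a 4-methoxyphenyl. They also leave open what a longer chain in place of that single carbon would do to the number.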